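Selenium in place of sulfur on a shared core

This account rests on a few compounds, and the source may have more. Where it says the series, first, only, none or still open, it means among the compounds named here.

compound 1 `CSc1ccc(CNc2nc([SeH])nc3ccccc23)cc1` — > 100000 nM
compound 2 `Sc1nc(NCc2ccccc2)c2ccccc2n1` — > 100000 nM

In a functional assay on MCF7 cells (Homo sapiens) for cytotoxicity, read by MTT assay, with a stated time of 72 h (a higher number here means that more compound is tolerated, a lower number that less compound is tolerated), compound 2 gives > 100000 nM, which is a limit of the assay and not a number. Compound 1 also stops at a limit, so both values sit at the limit of > 100000 nM in this assay, at which 2 of the 2 values shown sit. Compound 3 `[SeH]c1nc(NCc2ccccc2)c2ccccc2n1` differs from compound 2 by one selenium atom in place of one sulfur atom, on an aromatic carbon, in words one selenium atom in place of one sulfur atom, on an aromatic carbon. Among the measured compounds shown here, no measured step covers this change, so the expected step is a number no higher from compound 2 to compound 3 (the limit leaves the size open), nothing beyond the scatter. Compound 3 is therefore estimated at 100000 nM, between 30000 nM and 300000 nM, most likely reported only as a limit.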

Compound 3, concentration lethal to 50% of the cells: > 100000 nM
Compound 3: a limit, no number (the forecaster's own chance of this, stated with the estimate: 80%); the middle value lies on the limit itself.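

Compound 3 also stops at a limit, as do compound 1 and compound 2, so neither step to compound 3 can be read: the limit of > 100000 nM in this assay, at which 3 of the 3 values shown sit.

The compounds shown leave open how the selenium and sulfur compounds compare in this assay.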